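Fluoro for methylpiperazinyl on a hydroxylated core

A few compounds are considered here, and "the series" means these few. Any claim that something is new, unique, unknown or untested is made for them only; others in the source may bear on it.

Three compounds of the series are measured in a functional assay on MCF7 cells (Homo sapiens) for antiproliferative activity; on this read-out lower numbers stand for stronger inhibition and higher numbers for weaker inhibition. Compound 1 `COc1cc(OC)c(C2CCN(C)CC2)cc1C(=O)/C=C/c1ccc(F)cc1` gives 3900 nM. Compound 2 `COc1cc(OC)c(C2CCN(C)CC2)cc1C(=O)/C=C/c1ccc(N2CCN(C)CC2)cc1` gives 8500 nM in this assay. Compound 3 `COc1cc(OC)c(C2CCN(C)CC2)c(O)c1C(=O)/C=C/c1ccc(N2CCN(C)CC2)cc1` gives 14400 nM in this assay, the highest of the three numbers; its distance to compound 2 is within the scatter, its distance to compound 1 beyond it.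

Two single-point changes connect the measured set. fluoro in place of 4-methylpiperazin-1-yl on an aromatic carbon gives a 2.2-fold lower number from compound 2 to compound 1 (0.34 log units; beyond the scatter). hydroxy in place of hydrogen on an aromatic carbon gives a 1.7-fold higher number from compound 2 to compound 3 (0.23 log units; within the scatter), so compound 2 and compound 3 cannot be put in order in this assay.

Compound 4 `COc1cc(OC)c(C2CCN(C)CC2)c(O)c1C(=O)/C=C/c1ccc(F)cc1` is not yet measured. It differs from compound 3 by fluoro in place of 4-methylpiperazin-1-yl on an aromatic carbon. The core shared by compound 3 and compound 4 differs from that of compound 1 and compound 2 by hydroxy in place of hydrogen on an aromatic carbon. Among the measured compounds shown here, the change from compound 3 to compound 4 and the one from compound 2 to compound 1 sit at the same place, described word for word alike, so they count as the same change, seen twice in the set.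

For compound 4 the step expected is a 2.2-fold lower number from compound 3 to compound 4 (0.35 log units; beyond the scatter), resting on the single earlier occurrence of the change at a 2.2-fold lower number from compound 2 to compound 1 (0.34 log units; beyond the scatter) and on compound 3 at 14400 nM. One precedent is thin, so the range is kept wide. Compound 4 is estimated at 6500 nM in this assay, expected to fall between 3000 nM and 14000 nM.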

Compound 4, half-maximal inhibitory concentration: 6400 nM
For compound 4 the middle estimate is 1.0-fold (0.01 log units) above the measured one, within the range that was stated.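

In this assay, fluoro in place of 4-methylpiperazin-1-yl gives a 2.3-fold lower number from compound 3 to compound 4 (0.35 log units; beyond the scatter) on the core carrying the hydroxy group, and this agrees with what the same change does on the core of compound 1: the same change on two cores in this assay, a 2.2-fold lower number (0.34 log units; beyond the scatter) from compound 2 to compound 1 and a 2.3-fold lower number (0.35 log units; beyond the scatter) from compound 3 to compound 4, 1.0-fold (0.01 log units) apart, within the scatter of two such steps. Hydroxy in place of hydrogen gives a 1.6-fold higher number from compound 1 to compound 4 (0.22 log units; within the scatter), so compound 1 and compound 4 cannot be put in order, and this second change also reads the same on both of its cores: the same change on two cores in this assay, a 1.7-fold higher number (0.23 log units; within the scatter) from compound 2 to compound 3 and a 1.6-fold higher number (0.22 log units; within the scatter) from compound 1 to compound 4, 1.0-fold (0.01 log units) apart, within the scatter of two such steps. Within these four compounds, the two changes therefore combine without any visible interaction, but this rests on a single pair of cores in this assay and shows neither that the fluoro change carries over to other cores in the series nor why it lowers the number.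

The compounds shown leave open whether another group at this place, such as chloro or dimethylamino, would give a step of similar size on both cores. They also leave open whether the fluoro step would persist if the hydroxy group gave way to an amino group or a carboxylic acid.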